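Replacing the Carboxy Group of Compound 3 with a Pivaloyloxy Group

The source may report more compounds than this note shows. Statements on the series, on what has been measured and on what is new or still open speak of the compounds shown alone.

Measured compounds:
- compound 1, `Cc1nc2c(OCc3ccccc3)cccn2c1C(N)=O`: 42%
- compound 2, `CCOCc1c(C)nc2c(OCc3ccccc3)cccn12`: 84%
- compound 3, `Cc1nc2c(OCc3ccccc3)cccn2c1CC(=O)O`: 12%

Three compounds sharing one core were tested in a functional assay on the whole organism with Rattus norvegicus as the target, with a stated time of 4 h, at a dose of 40 mg/kg by the intraperitoneal route; on this read-out lower numbers stand for less inhibition and higher numbers for more inhibition at the one dose given (going by the name of the read-out). Compound 3 gives 12%, the lowest of the three numbers; its nearest neighbour is compound 1 with 42%, and the furthest is compound 2 with 84%. Both gaps lie beyond the scatter.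

The next compound, compound 4 (`Cc1nc2c(OCc3ccccc3)cccn2c1COC(=O)C(C)(C)C`), keeps the core of compound 3 but carries a different group on the saturated chain carbon bound to an aromatic carbon: ((tert-butyl)carbonyl)oxy in place of carboxy on a saturated chain carbon bound to an aromatic carbon

The step that bears most directly on this change is a number 72 percentage points lower from compound 2 to compound 3 (beyond the scatter), which shows that the carboxy group on that chain carbon goes with the lowest number in this assay, while the ethoxy group goes with the highest. The carbamoyl of compound 1 sits in between. Compound 4 removes the carboxy group altogether and brings in a group with no hydrogen-bond donor, as compound 2 does. A large upward step is therefore expected for compound 4, a number 53 percentage points higher from compound 3 to compound 4 (beyond the scatter), although the entering group is bulkier than anything measured here, so the range is wide. Compound 4 is estimated to give 65%, between 35% and 90%.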

Compound 4, a percentage reported as inhibition, in the whole organism at one dose (the size of the read-out at that dose, not a potency): 48%
Compound 4: middle estimate off by 17 percentage points, on the high side; the range from low to high includes it.
By their numbers in this assay, from the lowest: compound 3; then compounds 1 and 4 (each within the scatter of the next); then compound 2.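

Taking away the carboxy group is not enough on its own to reach the highest number: in this assay, ((tert-butyl)carbonyl)oxy in its place gives a number 36 percentage points higher from compound 3 to compound 4 (beyond the scatter). The absence of a hydrogen-bond donor on this chain therefore does not settle the outcome, since changing ethyl to (tert-butyl)carbonyl on the oxygen still gives a number 36 percentage points lower from compound 2 to compound 4 (beyond the scatter), although neither compound has such a donor there. The new group also cannot be told apart from carbamoyl in this assay, with a number 6 percentage points higher from compound 1 to compound 4 (within the scatter) a difference that does not separate the two.

Going by these compounds, it remains open whether a smaller acetyloxy group, a methoxy group or an amine on the same chain carbon would stand closer to compound 2 or to compound 3. Nothing measured here gives a reason for these steps.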